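Swapping the Ester on the Chain in B16 Cells

The source may report more compounds than this note shows. Statements on the series, on what has been measured and on what is new or still open speak of the compounds shown alone.

Compound 1 `C#Cc1ccc(NC(=O)c2cn(CC(=O)OCC)nn2)cc1`: > 100000 nM
Compound 2 `C#Cc1ccc(NC(=O)c2cn(CCOC(C)=O)nn2)cc1`: 79000 nM
Compound 3 `CCOC(=O)Cn1cc(C(=O)Nc2cccc(-c3cn(Cc4ccccc4)nn3)c2)nn1`: 20400 nM

Three compounds were tested in a functional assay on B16 cells (Mus musculus) for cytotoxicity, read by MTT assay, with a stated time of 48 h; a lower number here means a stronger inhibitor, a higher number a weaker inhibitor. For compound 1 the result is a limit of the assay, not a number (the limit of > 100000 nM in this assay, at which 1 of the 3 values shown sits). Compound 2 differs from compound 1 by acetoxymethyl in place of ethoxycarbonyl on a saturated chain carbon bound to an aromatic nitrogen, and this gave an at least 1.2-fold lower number from compound 1 to compound 2 (0.10 log units; that floor lies within the scatter). Compound 3 carries another core; the difference between the two cores is not broken down here. Of the two numbers recorded, compound 3 shows the lower one.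

Compound 4 `CC(=O)OCCn1cc(C(=O)Nc2cccc(-c3cn(Cc4ccccc4)nn3)c2)nn1` repeats the same change, (acetoxymethyl in place of ethoxycarbonyl on a saturated chain carbon bound to an aromatic nitrogen), at the same place. Because the earlier step of an at least 1.2-fold lower number from compound 1 to compound 2 (0.10 log units; that floor lies within the scatter) lay within the scatter, compound 4 is expected to sit near compound 3. The expected step is a 1.2-fold lower number from compound 3 to compound 4 (0.08 log units; within the scatter). The estimate for compound 4 in this assay is 17000 nM, between 6000 nM and 50000 nM.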

Compound 4, half-maximal inhibitory concentration: > 100000 nM
Compound 4 gave a limit, no number; the forecaster's own chance of this, stated with the estimate: 5%; middle value at least 5.8-fold (0.76 log units) from the limit.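

Carried to the core of compound 3, the change from ethoxycarbonyl to acetoxymethyl gave an at least 4.9-fold higher number from compound 3 to compound 4 (0.69 log units; beyond the scatter) in this assay. The result for compound 4, > 100000 nM, is a limit of the assay and not a number. The two pairs show that the step on the core of compound 1 did not carry over to the core of compound 3, but they do not show which part of the cores matters, how large the second step truly is, or that this holds across the series: the same change on two cores in this assay, an at least 1.2-fold lower number (0.10 log units; that floor lies within the scatter) from compound 1 to compound 2 and an at least 4.9-fold higher number (0.69 log units; beyond the scatter) from compound 3 to compound 4, at least 6.2-fold (0.79 log units) apart, beyond the scatter of two such steps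

The compounds shown leave open whether a carboxylic acid or a primary amide in place of ethoxycarbonyl would keep the value of compound 3. They also leave open how a longer chain carrying the ester would behave on either core.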